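Fluoro in place of propoxy on a well-tolerated series

The source may hold more compounds than are shown below. What is called first, only, known or untested is meant among the compounds shown, and "the series" means these compounds.

In a toxicity assay on MDCK cells (Canis lupus familiaris) for cytotoxicity, read by CCK-8 assay, with a stated time of 48 h (a higher number here means that more compound is tolerated, a lower number that less compound is tolerated), compound 1 `CCCOc1ccc(C(=O)NNc2c(Br)cccc2Br)cc1` gives only a limit, > 100000 nM. Compound 2 `COc1ccccc1C(=O)NNc1c(Br)cccc1Br` also gives only a limit, > 100000 nM. Compound 3 `COC(=O)c1ccc(C(=O)NNc2c(Br)cccc2Br)cc1` gives a number, 87600 nM. Compound 1 therefore has no exact value of its own and stands with the values at the limit of > 100000 nM in this assay, at which 2 of the 3 values shown sit.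

Compound 4 `O=C(NNc1c(Br)cccc1Br)c1ccc(F)cc1` differs from compound 1 as follows: fluoro in place of propoxy on an aromatic carbon. Fluoro takes the place of propoxy on an aromatic carbon, para to a large group. For the measured compounds named here, one measured step bears on this change, since it also removes the propoxy group: an at least 1.1-fold lower number from compound 1 to compound 3 (0.05 log units; that floor lies within the scatter). From the compounds shown here alone, that step gives only a floor, so its true size remains open. Even so, compound 3 at 87600 nM shows that a replacement of propoxy can leave the number high. No step beyond the scatter is therefore expected in this assay. The estimated step is an at least 1.1-fold lower number from compound 1 to compound 4 (0.04 log units; that floor lies within the scatter). Compound 4 is expected at 90000 nM, with an estimated range of 40000 nM to 150000 nM.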

Compound 4, half-maximal cytotoxic concentration: > 100000 nM
Compound 4 gave a limit, no number; the forecaster's own chance of this, stated with the estimate: 55%; middle value at least 1.1-fold (0.04 log units) from the limit.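

Para to a large group, propoxy can give way to fluoro and the reading in this assay still stays a limit, which the earlier compounds had not shown for this change: the limit of > 100000 nM in this assay, at which 3 of the 4 values shown sit. Fluoro in place of methoxycarbonyl gives an at least 1.1-fold higher number from compound 3 to compound 4 (0.05 log units; that floor lies within the scatter), so the two groups are not separated at this position. The step between compound 1 and compound 4 cannot be read, since both give only limits, and so any difference between propoxy and fluoro stays hidden.

The compounds shown leave open how far above the limit any of these compounds lies. They also leave open whether an amine, a carboxylic acid or a longer chain at this position would keep the reading at the limit or bring it down to a measurable number, as in compound 3.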